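The compounds below may be only part of what the source reports. "The series", "measured", "known", "first", "only" and "open" are said of these compounds alone.

Measured in a functional assay on A-375 cells (Homo sapiens) for activation, with a stated time of 3 days; on this read-out lower numbers stand for an effect already at smaller amounts and higher numbers for an effect only at larger amounts of compound:

- Compound 1 `O=C(Nc1ccc(-c2cscn2)cc1)C1CCCN(S(=O)(=O)c2ccc(F)c(F)c2)C1`: > 20000 nM (a limit of the assay)
- Compound 2 `O=C(Nc1ccc(-c2ccncc2)cc1)C1CCCN(Cc2ccc(F)c(F)c2)C1`: 1180 nM (a number)

Compound 1 gives only a limit. Among the measured compounds shown here, compound 2 holds the only actual number so far in this assay and is the sole numerical reference point. Compound 3 `O=C(Nc1ccc(-c2ncc[nH]2)cc1)C1CCCN(Cc2ccc(F)c(F)c2)C1` differs from compound 2 by 1H-imidazol-2-yl in place of pyridin-4-yl on an aromatic carbon (1H-imidazol-2-yl in place of pyridin-4-yl on an aromatic carbon, para to a large group). For the measured compounds named here, no measured step covers this exchange. A modest shift towards larger amounts is expected in this assay (estimated a 1.7-fold higher number from compound 2 to compound 3 (0.23 log units; within the scatter)). For compound 3 the estimated value is 2000 nM (expected range 500 nM to 8000 nM).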

Compound 3, half-maximal effective concentration: 8000 nM
The estimate for compound 3 lay 4.0-fold (0.60 log units) below the measured number; low and high end bracket the measured number.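

In this assay, among the compounds shown here, the exchange of pyridin-4-yl for 1H-imidazol-2-yl on this aromatic carbon gives a 6.8-fold higher number from compound 2 to compound 3 (0.83 log units; beyond the scatter) and is the first readable step at this position. The position therefore responds to the ring placed on it, and compound 3 still gives a real number rather than a limit. Room for reading weaker compounds is finite: the limit of > 20000 nM in this assay, at which 1 of the 3 values shown sits.

Ring size and the hydrogen-bond donor change together here, and the compounds shown do not separate them. A plain phenyl ring or a pyridin-3-yl group at this place is not among them.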